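Sulfonyl-for-carbonyl swap carried onto the longer chain

The source may hold more compounds than are shown below. What is called first, only, known or untested is meant among the compounds shown, and "the series" means these compounds.

Measured so far in a functional assay on MCF7 cells (Homo sapiens) for cytotoxicity, read by MTT assay, with a stated time of 48 h; on this read-out higher numbers stand for weaker inhibition and lower numbers for stronger inhibition:
- compound 1 `C/C=C/C=C/C(=O)N[C@H](C(=O)NCCCCCCCCCCCCCC)[C@@H](C)O` gives 27800 nM
- compound 2 `CCCCCCCCCCCCCCNC(=O)[C@@H](NS(=O)(=O)c1ccc(C)cc1)[C@@H](C)O` gives 12900 nM
- compound 3 `C/C=C/C=C/C(=O)N[C@H](C(=O)NCCCCCCCCCCCCCCCCCC)[C@@H](C)O` gives 79600 nM

Compound 2 differs from compound 1 by (4-methylphenyl)sulfonyl in place of (penta-1,3-dien-1-yl)carbonyl on an amine nitrogen, and this change reads as a 2.2-fold lower number from compound 1 to compound 2 (0.33 log units; beyond the scatter). Compound 3 differs from compound 1 by butyl in place of hydrogen on a saturated chain carbon, ten or more bonds along the chain from an amide-type nitrogen, which reads as a 2.9-fold higher number from compound 1 to compound 3 (0.46 log units; beyond the scatter); compound 3 thus carries the highest number of the three, with compound 2 furthest from it.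

Compound 4 `CCCCCCCCCCCCCCCCCCNC(=O)[C@@H](NS(=O)(=O)c1ccc(C)cc1)[C@@H](C)O` is not yet measured. It differs from compound 3 by (4-methylphenyl)sulfonyl in place of (penta-1,3-dien-1-yl)carbonyl on an amine nitrogen, the same change that leads from compound 1 to compound 2, made on the core of compound 3 rather than the core of compound 1; the two cores differ as given above for compound 3 against compound 1. The surroundings of the nitrogen are the same in both pairs, so the change is taken as the same.

Only one worked example of this change exists, so the expectation for compound 4 rests on that single step. For compound 4 the step from compound 3 is expected to be about a 2.2-fold lower number from compound 3 to compound 4 (0.34 log units; beyond the scatter), because the earlier pair showed a 2.2-fold lower number from compound 1 to compound 2 (0.33 log units; beyond the scatter). Compound 4 is therefore estimated at 36000 nM in this assay, with a plausible range from 15000 nM to 90000 nM.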

Compound 4, half-maximal inhibitory concentration: 60100 nM
Estimate against measurement, compound 4: 1.7-fold (0.22 log units) below; the range from low to high includes it.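

In this assay, placing (4-methylphenyl)sulfonyl on the amine nitrogen of the longer-chain core gives a 1.3-fold lower number from compound 3 to compound 4 (0.12 log units; within the scatter), and the comparison with the same change on the shorter-chain core shows no separable difference: the same change on two cores in this assay, a 2.2-fold lower number (0.33 log units; beyond the scatter) from compound 1 to compound 2 and a 1.3-fold lower number (0.12 log units; within the scatter) from compound 3 to compound 4, 1.6-fold (0.21 log units) apart, within the scatter of two such steps The butyl-for-hydrogen chain change, read on the sulfonyl-bearing core, gives a 4.7-fold higher number from compound 2 to compound 4 (0.67 log units; beyond the scatter), and it too keeps its size within what repeated measurements allow: the same change on two cores in this assay, a 2.9-fold higher number (0.46 log units; beyond the scatter) from compound 1 to compound 3 and a 4.7-fold higher number (0.67 log units; beyond the scatter) from compound 2 to compound 4, 1.6-fold (0.21 log units) apart, within the scatter of two such steps Together the two comparisons fit both changes carrying over from one core to the other, but they rest on a single square of compounds, and since the sulfonyl step is beyond the scatter on one core and within it on the other, they do not establish that this step is a real shift on the longer-chain core.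

The compounds shown leave open how the nitrogen change behaves on a shorter chain such as decyl, and whether the chain change continues in the same direction with a longer chain. They also leave open whether another group on the amine nitrogen, such as benzoyl or a plain phenylsulfonyl, would read like (4-methylphenyl)sulfonyl.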